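Shifting the acid arm on the anilide ring

The compounds below may be only part of what the source reports. "The series", "measured", "known", "first", "only" and "open" are said of these compounds alone.

Compound 1 `CC(C)(C)C(=O)CN1C(=O)N(CC(=O)Nc2cccc(-c3nc(=O)o[nH]3)c2)N=C(C2CCCCC2)c2ccccc21` gives 589 nM in an assay on CHO-K1 cells for displacement of a labelled ligand from Cholecystokinin receptor type A (Homo sapiens) (on this read-out lower numbers stand for stronger inhibition and higher numbers for weaker inhibition), and compound 3 `CC(C)(C)C(=O)CN1C(=O)N(CC(=O)Nc2ccc3ccn(CC(=O)O)c3c2)N=C(C2CCCCC2)c2ccccc21` gives 550 nM. Compound 2 `CC(C)(C)C(=O)CN1C(=O)N(CC(=O)Nc2cccc(CCC(=O)O)c2)N=C(C2CCCCC2)c2ccccc21` reaches only the limit of > 10000 nM, not a number. That limit follows the step of an at least 16-fold higher number from compound 1 to compound 2 (1.22 log units; beyond the scatter), where the five-membered ring was replaced by 2-carboxyethyl; the same limit appears as the limit of > 10000 nM in this assay, at which 1 of the 3 values shown sits. Compound 4 `CN(CC(=O)O)c1cccc(NC(=O)CN2N=C(C3CCCCC3)c3ccccc3N(CC(=O)C(C)(C)C)C2=O)c1` changes compound 2 by (carboxymethyl)(methyl)amino in place of 2-carboxyethyl on an aromatic carbon. Among the measured compounds shown here, the only measured step touching this position is the large loss from compound 1 to compound 2, so an acid hung on a short flexible chain here has so far given a limit. Compound 4 is expected to move only modestly, with a step of an at least 2.0-fold lower number from compound 2 to compound 4 (0.30 log units; that floor lies within the scatter), to an estimated 5000 nM (range 1000 nM to 20000 nM).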

Compound 4, inhibition constant: 6460 nM
Estimate against measurement, compound 4: 1.3-fold (0.11 log units) below, within the range that was stated.
By their numbers in this assay, from the lowest: compounds 3 and 1 (each within the scatter of the next); then compound 4. At a limit, above all of these: compound 2.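

Compound 4 gives an open-chain acid at this position its first true number, whereas compound 2 holds only a limit: the limit of > 10000 nM in this assay, at which 1 of the 4 values shown sits. With a step of an at least 1.5-fold lower number from compound 2 to compound 4 (0.18 log units; that floor lies within the scatter), it cannot be said that (carboxymethyl)(methyl)amino improves on 2-carboxyethyl. The open chain still falls well short of the five-membered aromatic ring, with an 11-fold higher number from compound 1 to compound 4 (1.04 log units; beyond the scatter).

As far as these compounds go, it remains open whether a tetrazole at the end of this chain, in place of the carboxylic acid, would bring the number back toward that of compound 1.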